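Replacing cyclopropyl with a hydroxyalkyl group on the core

The compounds below may be only part of what the source reports. "The series", "measured", "known", "first", "only" and "open" are said of these compounds alone.

In an ADME assay on microsomes (Mus musculus) for pharmacokinetics (on this read-out lower numbers stand for slow clearance and higher numbers for fast clearance), compound 2 `CN1CCN(c2ccc(Nc3ncc4c(=O)c(-c5c(Cl)cccc5Cl)cn(C5CC5)c4n3)cc2)CC1` gives 582 mL/min/kg, the highest of the two numbers measured; compound 1 `CN1CCN(c2ccc(Nc3ncc4c(=O)c(-c5c(Cl)cccc5Cl)cn(C)c4n3)cc2)CC1` gives 270 mL/min/kg. Compound 3 `CN1CCN(c2ccc(Nc3ncc4c(=O)c(-c5c(Cl)cccc5Cl)cn(CC(C)(C)O)c4n3)cc2)CC1` differs from compound 2 by 2-hydroxy-2-methylpropyl in place of cyclopropyl on an aromatic nitrogen. Among the measured compounds shown here, the only measured step at this aromatic nitrogen is a 2.2-fold higher number from compound 1 to compound 2 (0.33 log units; beyond the scatter), which shows that this position can shift this assay, but no step shows a change of this kind. Compound 3 is therefore expected to fall between the two measured numbers, with a 1.7-fold lower number from compound 2 to compound 3 (0.22 log units; within the scatter) as the estimated step, giving 350 mL/min/kg within a range of 150 mL/min/kg to 750 mL/min/kg.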

Compound 3, clearance: 482 mL/min/kg
Compound 3: the middle estimate sits 1.4-fold (0.14 log units) below what was measured, within the range that was stated.
By their numbers in this assay, from the lowest: compounds 1, 3 and 2 (each within the scatter of the next, the first and the last beyond it).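

In this assay, the open-chain 2-hydroxy-2-methylpropyl group, with its hydrogen-bond donor and acceptor, cannot be told apart from cyclopropyl at this aromatic nitrogen (a 1.2-fold lower number from compound 2 to compound 3 (0.08 log units; within the scatter)). It also cannot be told apart from methyl (a 1.8-fold higher number from compound 1 to compound 3 (0.25 log units; within the scatter)), so compound 3 stays within the scatter of both compound 1 and compound 2, although those two differ beyond it. Adding the hydroxyl-bearing chain at this position therefore gives no clear change in this read-out. As far as these compounds go, whether an amine or a carboxylic acid on this chain, or a longer chain, would move the number beyond the scatter remains open. Nothing available gives a reason for these numbers.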